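Adding a Fluoro Group to Compound 2

A few compounds are considered here, and "the series" means these few. Any claim that something is new, unique, unknown or untested is made for them only; others in the source may bear on it.

In a functional assay on MCF7 cells (Homo sapiens) for cytotoxicity, read by MTT assay, with a stated time of 72 h (on this read-out higher numbers stand for weaker inhibition and lower numbers for stronger inhibition), compound 2 `Cc1ccc(-c2ccc([N+](=O)[O-])cc2)n1-c1ccc(-c2nc3ccccc3s2)cc1` gives 3110 nM. Compound 1 `COc1ccc(-c2ccc(C)n2-c2ccc(-c3nc4ccccc4s3)cc2)cc1` gives 3260 nM, and the step of a 1.0-fold lower number from compound 1 to compound 2 (0.02 log units; within the scatter) means the two numbers cannot be told apart. Compound 3 `Cc1ccc(-c2ccc([N+](=O)[O-])cc2)n1-c1ccc(-c2nc3ccc(F)cc3s2)cc1` differs from compound 2 by fluoro in place of hydrogen on an aromatic carbon, turning the 1,3-benzothiazol-2-yl into 6-fluoro-1,3-benzothiazol-2-yl. Among the measured compounds shown here, no measured step covers this kind of change; the only known step, nitro in place of methoxy, concerns a different group and stayed within the scatter. The expected step of a 1.0-fold lower number from compound 2 to compound 3 (0.00 log units; within the scatter) is therefore none beyond the scatter. Compound 3 is estimated at 3100 nM, with a range from 1200 nM to 8000 nM.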

Compound 3, half-maximal inhibitory concentration: 2370 nM
Compound 3: the middle estimate sits 1.3-fold (0.12 log units) above what was measured; the measured number falls inside the stated range.
By their numbers in this assay, from the lowest: compounds 3, 2 and 1 (each within the scatter of the next).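

In this assay the swap of fluoro for hydrogen on this six-membered aromatic ring of carbon only gives a 1.3-fold lower number from compound 2 to compound 3 (0.12 log units; within the scatter) and so leaves 6-fluoro-1,3-benzothiazol-2-yl and 1,3-benzothiazol-2-yl indistinguishable here. This is the first change shown on this part of the molecule, and with nitro held constant, this single fluorine does not shift the number beyond the scatter. No supporting measurement is available to explain this result.

From the compounds shown here alone, whether an amine or a carboxylic acid at this same position would move the number remains open. So does whether fluoro would behave the same way with methoxy in place of nitro.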